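Adding a Methyl to the Amide Nitrogen of Compound 2

The source may hold more compounds than are shown below. What is called first, only, known or untested is meant among the compounds shown, and "the series" means these compounds.

Two compounds have been measured in a functional assay on RPMI18226 cells (Homo sapiens) for antiproliferative activity, read by sulforhodamine B assay, with a stated time of 48 h, tested at 10 uM; a higher number here means more inhibition at the concentration tested (going by the name of the read-out), a lower number less inhibition:
compound 1 `COc1ccc([C@@H]2CN(C)[C@]3(C(=O)N(C)c4ccccc43)[C@]23Cc2ccccc2C3=O)cc1` gives 82.3%
compound 2 `CN1C[C@@H](c2cccs2)[C@@]2(Cc3ccccc3C2=O)[C@@]12C(=O)Nc1ccccc12` gives 10.9%

Compound 2 stands at the bottom of these two numbers; compound 1 sits far above it, and the gap between them is well beyond the scatter of repeated runs. The two compounds differ in more than one place, so the gap cannot be traced to any single part of the structure.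

Compound 3 `CN1C(=O)[C@@]2(c3ccccc31)N(C)C[C@@H](c1cccs1)[C@@]21Cc2ccccc2C1=O` is the next compound to be measured. It differs from compound 2 in one place: methyl in place of hydrogen on an amide-type nitrogen in a ring. Among the compounds with values here, compound 1, the one with the higher number, carries a methyl on its amide nitrogen as well, but it also bears a different aryl group, so the methyl alone cannot be credited with its higher inhibition in this assay.

The expectation for compound 3 is a rise in inhibition over compound 2, of uncertain size, estimated as the step of a number 34.1 percentage points higher from compound 2 to compound 3 (beyond the scatter) in this assay. Compound 3 is accordingly estimated at 45%, within a range from 15% to 80%.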

Compound 3, a percentage reported as inhibition, at one concentration (the size of the read-out at that concentration, not a potency): 12.1%
Beside the measured number, compound 3's estimate is 32.9 percentage points above it, and the stated range ends above it.
By their numbers in this assay, from the lowest: compounds 2 and 3 (each within the scatter of the next); then compound 1.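

In this assay, methyl in place of hydrogen on the amide-type nitrogen in a ring gives a number 1.2 percentage points higher from compound 2 to compound 3 (within the scatter), so with thiophen-2-yl on the saturated ring carbon, this swap on the nitrogen leaves no effect that can be told from the scatter. Within the data shown here, compound 3 also gives the first comparison with the methyl present on both sides, where thiophen-2-yl in place of 4-methoxyphenyl on a saturated ring carbon gives a number 70.2 percentage points lower from compound 1 to compound 3 (beyond the scatter), a large step that for this pair belongs to that single change of aryl group. Nothing measured here explains either result.

The compounds shown leave open whether the methyl step would stay this small with 4-methoxyphenyl on the saturated ring carbon, and how an ethyl group or a longer chain on the same nitrogen would read in this assay. Also open, going by these compounds, is which part of 4-methoxyphenyl matters for the large step, a question that a plain phenyl group or a 4-chlorophenyl group on that carbon could begin to separate.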